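The source may report more compounds than this note shows. Statements on the series, on what has been measured and on what is new or still open speak of the compounds shown alone.

Compound 1 `Cn1cc(-c2ccc(F)cc2)c(=O)c2c(Nc3ccc(Oc4ccnc(NC(=O)C5CC5)c4)c(F)c3)nccc21`: 24.8%
Compound 2 `CC(=O)Nc1cc(Oc2ccc(Nc3nccc4[nH]cc(-c5ccc(F)cc5)c(=O)c34)cc2F)ccn1`: 36.8%

Within the data shown here, in a functional assay on HT-29 cells (Homo sapiens) for antiproliferative activity, read by MTT assay, with a stated time of 72 h, tested at 10 uM (a higher number here means more inhibition at the concentration tested (going by the name of the read-out), a lower number less inhibition), compound 2 gives the higher of these two numbers; the only other number, that of compound 1, lies lower by a gap beyond the usual scatter. Compound 3 `CCC(=O)Nc1cc(Oc2ccc(Nc3nccc4[nH]cc(-c5ccc(F)cc5)c(=O)c34)cc2F)ccn1` differs from compound 2 by methyl in place of hydrogen on a saturated chain carbon bound to a carbonyl carbon. Among the measured compounds shown here, no pair of measured compounds shows a step of this kind, so nothing here tells how large its effect is. A step no bigger than the scatter is expected, a number 0.2 percentage points higher from compound 2 to compound 3 (within the scatter), in no settled direction. For compound 3 the estimate in this assay is 37%, expected to lie between 22% and 52%.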

Compound 3, a percentage reported as inhibition, at one concentration (the size of the read-out at that concentration, not a potency): 68.7%
Compound 3: the middle estimate sits 31.7 percentage points below what was measured; the measured number lies above the stated range.
By their numbers in this assay, from the lowest: compound 1; then compound 2; then compound 3.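

In this assay, the change from acetamido to propanoylamino gives a number 31.9 percentage points higher from compound 2 to compound 3 (beyond the scatter), so one added methyl on a saturated chain carbon bound to a carbonyl carbon can shift this number well beyond the scatter. The earlier compounds shown here offered no pair that differed at this place, so they could not show how much it matters. Nothing measured here accounts for the size of this step. From the compounds shown here alone, a single step sets no trend, so it remains open whether a longer chain, such as butanoylamino, would raise the number further or lower it.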